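A few compounds are considered here, and "the series" means these few. Any claim that something is new, unique, unknown or untested is made for them only; others in the source may bear on it.

Working notes on the series. Compound 1 `OC[C@@H](O[C@H]1CCCN(Cc2ncc[nH]2)[C@H]1c1ccccc1)c1cc(Cl)cc(Cl)c1` is the anchor; in an assay on isolated protein for activation of cGMP-dependent protein kinase 1 (Homo sapiens), read by ADP-Glo, with stated times of 30 min and 2 h (a higher number here means that more compound is needed for the effect, a lower number that less compound is needed), compound 1 gives only a limit of the assay, > 200000 nM. Compound 2 `O=C(O)c1ccc(CN2CCC[C@H](O[C@H](CO)c3cc(Cl)cc(Cl)c3)[C@@H]2c2ccccc2)cc1` gives 77000 nM in this assay, and compound 3 `COC(=O)Nc1cc(C(=O)O)ccc1CN1CCC[C@H](O[C@H](CO)c2cc(Cl)cc(Cl)c2)[C@@H]1c1ccccc1` gives 69000 nM. Among the two numbers shown, compound 2 stands highest, with compound 3 nearest; the step of a 1.1-fold lower number from compound 2 to compound 3 (0.05 log units; within the scatter) lies within the scatter, so no order is drawn between them. The step of an at least 2.5-fold lower number from compound 1 to compound 2 (0.41 log units; beyond the scatter) is the only one beyond the scatter, and it rests on the limit (the limit of > 200000 nM in this assay, at which 1 of the 3 values shown sits).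

Compound 4 `Cc1cc(C(=O)O)ccc1C(=O)N1CCC[C@H](O[C@H](CO)c2cc(Cl)cc(Cl)c2)[C@@H]1c1ccccc1` is not yet measured. Against compound 2 the change is a group of 12 heavy atoms (9 carbon, 3 oxygen; one six-membered aromatic ring of carbon only) in place of a group of 10 heavy atoms (8 carbon, 2 oxygen; one six-membered aromatic ring of carbon only), on an amine nitrogen in a ring. The step of a 1.1-fold lower number from compound 2 to compound 3 (0.05 log units; within the scatter) altered the aromatic ring of this same group and stayed within the scatter; the step of an at least 2.5-fold lower number from compound 1 to compound 2 (0.41 log units; beyond the scatter) replaced the whole group and was at least modest. Neither covers this exact change, so the expected step of a 1.3-fold higher number from compound 2 to compound 4 (0.11 log units; within the scatter) is none beyond the scatter. Compound 4 is therefore expected at 100000 nM, within 30000 nM to 300000 nM in this assay.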

Compound 4, half-maximal effective concentration: > 200000 nM
Compound 4 was reported as a limit; the forecaster's own chance of this, stated with the estimate: 25%; at least 2.0-fold (0.30 log units) between middle value and limit.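

In this assay, the amine nitrogen in a ring turns out to respond to a change that keeps the aromatic ring and the carboxylic acid of the group on it: an at least 2.5-fold higher number from compound 2 to compound 4 (0.41 log units; beyond the scatter), whereas the earlier change on that aromatic ring, a 1.1-fold lower number from compound 2 to compound 3 (0.05 log units; within the scatter), stayed within the scatter. This step rests on the value of compound 4, which is a limit and not a number: the limit of > 200000 nM in this assay, at which 2 of the 4 values shown sit. The step between compound 1 and compound 4 cannot be read, since both values are limits.

Compound 4 brings a carbonyl on the amine nitrogen and a methyl on the aromatic ring in a single change, so the compounds shown do not tell which of the two carries the step. As far as these compounds go, what a 4-carboxybenzoyl group without the methyl would give stays open, as does the effect of a longer chain on that nitrogen.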